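A few compounds are considered here, and "the series" means these few. Any claim that something is new, unique, unknown or untested is made for them only; others in the source may bear on it.

The series shares one core and differs only in the aromatic ring attached to it. Compound 1 `O=C1C=CC(OCC(F)(F)F)N1c1cc(Cl)cc(Cl)c1` gives 5920 nM in a functional assay on HeLa cells (Homo sapiens) for inhibition (a lower number here means a stronger inhibitor, a higher number a weaker inhibitor), compound 3 `O=C1C=CC(OCC(F)(F)F)N1c1ccc(F)c(Cl)c1` gives 3110 nM, and compound 2 `CCc1ccc(N2C(=O)C=CC2OCC(F)(F)F)cc1` gives 6510 nM. Compound 2 thus shows the highest of the three numbers; its value and that of compound 1 sit within the scatter of each other, while compound 3 gives a lower number by a margin beyond the scatter. Compound 4 `O=C1C=CC(OCC(F)(F)F)N1c1ccc(Br)cc1` is not yet measured. It differs from compound 2 by bromo in place of ethyl on an aromatic carbon. Among the compounds with values here, no pair of measured compounds isolates this change. The expected step is a 1.3-fold lower number from compound 2 to compound 4 (0.11 log units; within the scatter), small and not beyond the scatter in either direction. Compound 4 is therefore estimated at 5000 nM, with a range from 2000 nM to 12500 nM.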

Compound 4, half-maximal inhibitory concentration: 7060 nM
The estimate for compound 4 lay 1.4-fold (0.15 log units) below the measured number; the measured number falls inside the stated range.
By their numbers in this assay, from the lowest: compounds 3, 1, 2 and 4 (each within the scatter of the next, the first and the last beyond it).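

In this assay, bromo in place of ethyl on the aromatic carbon para to a large group gives a 1.1-fold higher number from compound 2 to compound 4 (0.04 log units; within the scatter) and so leaves the number unchanged within the scatter. Within the data shown here, this is the first pair to isolate a single change, and at this position it does not separate the two groups. Nothing at hand bears on why the two groups read alike.

On these data alone, whether an amine, a carboxylic acid or a longer chain at this position would shift the number remains open.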